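The compounds below may be only part of what the source reports. "The series", "measured", "known", "first", "only" and "open" are said of these compounds alone.

Working notes on the series. Compound 1 `CC1=C(C(=O)OCC(C)C)C(c2ccco2)NC(=O)N1C` is the reference point; in an assay on membranes from HeLa cells for displacement of a labelled ligand from adenosine receptor A3 (Homo sapiens), read by scintillation counting, with a stated time of 180 min, tested at 1 uM (on this read-out higher numbers stand for more inhibition at the one concentration tested (going by the name of the read-out) and lower numbers for less inhibition), compound 1 gives 23%. Compound 2 `CC1=C(C(=O)OC(C)(C)C)C(c2ccco2)NC(=O)N1C` differs from it by tert-butyl in place of isobutyl on an oxygen next to a carbonyl group, and this single change moves the read-out by a number 31 percentage points higher from compound 1 to compound 2 (beyond the scatter), so that in this assay compound 2 gives 54%. Compound 3 `CC1=C(C(=O)OCC(C)C)C(c2ccsc2)NC(=O)N1C` keeps the isobutyl ester of compound 1 but its core differs by thiophen-3-yl in place of furan-2-yl on a saturated ring carbon; that change costs a number 19 percentage points lower from compound 1 to compound 3 (beyond the scatter), and in this assay compound 3 gives 4%, the lowest of the three numbers.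

Compound 4 `CC1=C(C(=O)OC(C)(C)C)C(c2ccsc2)NC(=O)N1C` has not yet been run. Within the data shown here, it differs from compound 3 by tert-butyl in place of isobutyl on an oxygen next to a carbonyl group, which is the same change, at the same place, as the one from compound 1 to compound 2. The expected step for compound 4 is a number 26 percentage points higher from compound 3 to compound 4 (beyond the scatter), resting on one observed case, the step of a number 31 percentage points higher from compound 1 to compound 2 (beyond the scatter), and on compound 3 starting from 4%. Accordingly, in this assay compound 4 is estimated at 30%, within a range from 10% to 55%.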

Compound 4, a percentage reported as inhibition, at one concentration (the size of the read-out at that concentration, not a potency): 14%
Compound 4: middle estimate off by 16 percentage points, on the high side, within the range that was stated.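

Carried to the core of compound 3, tert-butyl in place of isobutyl on an oxygen next to a carbonyl group gives a number 10 percentage points higher from compound 3 to compound 4 (within the scatter) in this assay, so the gain seen on the core of compound 1 does not carry over at the same size: the same change on two cores in this assay, a number 31 percentage points higher (beyond the scatter) from compound 1 to compound 2 and a number 10 percentage points higher (within the scatter) from compound 3 to compound 4, 21 percentage points apart, beyond the scatter of two such steps

Read the other way, thiophen-3-yl in place of furan-2-yl on a saturated ring carbon gives a number 40 percentage points lower from compound 2 to compound 4 (beyond the scatter) and also depends on the ester group it is paired with: the same change on two cores in this assay, a number 19 percentage points lower (beyond the scatter) from compound 1 to compound 3 and a number 40 percentage points lower (beyond the scatter) from compound 2 to compound 4, 21 percentage points apart, beyond the scatter of two such steps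

The two changes are therefore not additive in this square of four compounds, but a single square read at one concentration does not show why, nor how either change would behave on any other core. The compounds shown leave open whether this dependence extends to other ester groups, such as a longer chain like n-hexyl or a cyclohexyl ester, or to other rings on the saturated ring carbon, such as phenyl or pyridine. They also leave open how these single-concentration numbers relate to potency.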